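A few compounds are considered here, and "the series" means these few. Any claim that something is new, unique, unknown or untested is made for them only; others in the source may bear on it.

In a toxicity assay on MT4 cells (Homo sapiens) for cytotoxicity, read by MTT assay, with a stated time of 5 days (a lower number here means that less compound is tolerated, a higher number that more compound is tolerated), compound 1 `Cc1cc(-c2cc3ccccc3s2)cc(C)c1Nc1ccnc(Nc2ccc(C#N)cc2)n1` gives 138000 nM and compound 2 `COc1ncc(-c2cc(C)c(Nc3ccnc(Nc4ccc(C#N)cc4)n3)c(C)c2)cn1` gives 4800 nM. Compound 2 therefore holds the lower of the two numbers, meaning less of it is tolerated. Compound 3 `Cc1cc(-c2cnc(C#N)nc2)cc(C)c1Nc1ccnc(Nc2ccc(C#N)cc2)n1` has not yet been measured. It differs from compound 2 at one place, where 2-methoxypyrimidin-5-yl becomes 2-cyanopyrimidin-5-yl: cyano in place of methoxy on an aromatic carbon. Among the measured compounds shown here, the only measured step that bears on this is a 29-fold lower number from compound 1 to compound 2 (1.46 log units; beyond the scatter). That large step came from exchanging one whole ring-bearing group for another, 1-benzothiophen-2-yl for 2-methoxypyrimidin-5-yl, whereas here only methoxy gives way to cyano. No measurement covers this smaller exchange directly, so no step beyond the scatter is expected in this assay, and neither direction is favoured. The expected step is a 1.0-fold higher number from compound 2 to compound 3 (0.02 log units; within the scatter). For compound 3 the estimated value is 5000 nM, with an expected range of 1500 nM to 25000 nM.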

Compound 3, half-maximal cytotoxic concentration: 3100 nM
The estimate for compound 3 lay 1.6-fold (0.21 log units) above the measured number, within the range that was stated.
By their numbers in this assay, from the lowest: compounds 3 and 2 (each within the scatter of the next); then compound 1.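

In this assay, cyano on the aromatic carbon between two ring nitrogen atoms gives a 1.5-fold lower number from compound 2 to compound 3 (0.19 log units; within the scatter) and so cannot be told apart from methoxy at this position. Keeping the cyano and comparing with the 1-benzothiophen-2-yl of compound 1 gives a 45-fold lower number from compound 1 to compound 3 (1.65 log units; beyond the scatter) as a second large step, so both pyrimidine-bearing compounds stand well apart from compound 1 in this assay. No measurement available here explains either step.

The compounds shown leave open whether an amine or a carboxylic acid on this same carbon would stay as close to these numbers, or whether a longer chain there would produce a step beyond the scatter. Methoxy and cyano are the only two groups compared at this position, so their agreement cannot be extended to other groups.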